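The source may hold more compounds than are shown below. What is called first, only, known or untested is meant among the compounds shown, and "the series" means these compounds.

Measured so far:

- compound 1 `COc1cc(-c2cc(/C=C/C(=O)c3ccc(Cl)c(Cl)c3)[nH]n2)cc(OC)c1OC`: 3200 nM
- compound 2 `COc1cc(-c2cc(/C=C/C(=O)c3ccccc3)[nH]n2)cc(OC)c1OC`: 2100 nM

In a functional assay on MCF7 cells (Homo sapiens) for inhibition, read by MTT assay, with a stated time of 48 h (a higher number here means a weaker inhibitor, a lower number a stronger inhibitor), compound 2 gives 2100 nM, the lowest of the two numbers; its nearest neighbour, compound 1, gives 3200 nM, and the step of a 1.5-fold lower number from compound 1 to compound 2 (0.18 log units; within the scatter) is within the scatter, so no order between the two can be read from these values.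

Compound 3 `COc1cc(-c2cc(/C=C/C(C)=O)[nH]n2)cc(OC)c1OC` is not yet measured. It differs from compound 2 by methyl in place of phenyl on a carbonyl carbon. Within the data shown here, the only step measured exchanges one aryl group for another on the same carbonyl carbon, and a 1.5-fold lower number from compound 1 to compound 2 (0.18 log units; within the scatter) moved the number by little. Among the measured compounds shown here, no measured step removes the aromatic ring at that position altogether, so nothing here tells directly how the change to methyl will read in this assay. With the whole ring leaving, a step larger than that between compound 1 and compound 2 is considered possible, and the direction is taken as toward a higher number, that is a weaker inhibitor, while a number within the scatter of compound 2 cannot be excluded.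

For compound 3 the expected step is a 3.1-fold higher number from compound 2 to compound 3 (0.49 log units; beyond the scatter), and the estimate is 6500 nM with a range from 2000 nM to 25000 nM.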

Compound 3, half-maximal inhibitory concentration: 20100 nM
Estimate against measurement, compound 3: 3.1-fold (0.49 log units) below, and the stated range covers the measured number.
By their numbers in this assay, from the lowest: compounds 2 and 1 (each within the scatter of the next); then compound 3.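

In this assay, the group on the carbonyl carbon now shows a change beyond the scatter: replacing phenyl with methyl gives a 9.6-fold higher number from compound 2 to compound 3 (0.98 log units; beyond the scatter), and replacing 3,4-dichlorophenyl with methyl gives a 6.3-fold higher number from compound 1 to compound 3 (0.80 log units; beyond the scatter). The earlier exchange of one aryl group for another gave only a 1.5-fold lower number from compound 1 to compound 2 (0.18 log units; within the scatter), so the two aryl compounds cannot be told apart, while the methyl compound stands clearly apart from both, and this position responds to the loss of the ring far more than to the difference between these two rings. Nothing available explains the size or direction of this step.

Open, on these data alone, is whether the aromatic ring itself matters or simply the amount of carbon on the carbonyl carbon, a question that a longer chain such as n-butyl, or a saturated ring such as cyclohexyl, would help to separate from the present result. Also open, as far as these compounds go, is how far the aryl position stays flat beyond phenyl and 3,4-dichlorophenyl, for instance with a pyridine ring or with a phenyl ring carrying an amine or a carboxylic acid.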